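Eight-substituent variation in a dipropylxanthine series

The source may hold more compounds than are shown below. What is called first, only, known or untested is meant among the compounds shown, and "the series" means these compounds.

Measured so far:
compound 1 `CCCn1c(=O)c2nc(-c3cccn3C)[nH]c2n(CCC)c1=O` — 140 nM
compound 2 `CCCn1c(=O)c2nc(CC(C)(C)C)[nH]c2n(CCC)c1=O` — 49 nM

Both compounds share the same core and differ only in the group on the aromatic carbon of the five-membered ring. In an assay on cell membranes for binding affinity to adenosine receptor A1 (Cavia porcellus), read by radioligand binding (a lower number here means a stronger inhibitor, a higher number a weaker inhibitor), compound 1 gives 140 nM, and compound 2 gives 49 nM. Among the compounds with values here, the single measured step, a 2.9-fold lower number from compound 1 to compound 2 (0.46 log units; beyond the scatter), places compound 2 as the lower of the two numbers, with compound 1 as its only neighbour.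

Compound 3 `CCCn1c(=O)c2nc(C(C)(C)C)[nH]c2n(CCC)c1=O` is not yet measured. The change from compound 2 is tert-butyl in place of neopentyl on an aromatic carbon. Within the data shown here, the one measured step, from an aromatic ring substituent to neopentyl, does not involve the shortening of a saturated branched group and so bears only loosely on this change; no measured pair compares tert-butyl with neopentyl. With nothing in the measured data pointing in either direction, the expectation for this assay is a step of no clear size beyond the scatter, written as a 1.2-fold higher number from compound 2 to compound 3 (0.09 log units; within the scatter). Compound 3 is therefore estimated at 60 nM, with a range from 20 nM to 180 nM.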

Compound 3, inhibition constant: 31 nM
The estimate for compound 3 lay 1.9-fold (0.29 log units) above the measured number; the range from low to high includes it.
By their numbers in this assay, from the lowest: compounds 3 and 2 (each within the scatter of the next); then compound 1.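

In this assay the exchange of neopentyl for tert-butyl, on an aromatic carbon between two ring nitrogen atoms, gives a 1.6-fold lower number from compound 2 to compound 3 (0.20 log units; within the scatter) and so cannot be read as a gain or a loss: at this position the two saturated branched groups, each with no ring and no hydrogen-bond donors or acceptors, are not told apart. What compound 3 adds is a second branched alkyl group that stands clear of the 1-methyl-1H-pyrrol-2-yl group of compound 1, with a 4.5-fold lower number from compound 1 to compound 3 (0.65 log units; beyond the scatter) alongside the earlier 2.9-fold lower number from compound 1 to compound 2 (0.46 log units; beyond the scatter) and no compound shown going against this within the three. No supporting data bear on why these numbers fall as they do.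

Still open, on these data alone, is whether branching matters at all, which an unbranched chain such as n-butyl would test, and whether a saturated ring such as cyclopentyl or cyclohexyl fits with neopentyl and tert-butyl. Also open, as far as these compounds go, is whether the higher number of compound 1 belongs to the aromatic ring or to its methyl group, which an unsubstituted pyrrol-2-yl or a phenyl group would help to separate.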